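From pyridin-3-yl to 3-aminophenyl on a shared core

A few compounds are considered here, and "the series" means these few. Any claim that something is new, unique, unknown or untested is made for them only; others in the source may bear on it.

Of the compounds shown here, three sharing one core have been tested in a functional assay on MCF7 cells (Homo sapiens) for inhibition, read by sulforhodamine B assay, with a stated time of 48 h; a lower number here means a stronger inhibitor of growth, a higher number a weaker inhibitor of growth. Compound 1 `COC(=O)c1sc2cc(-c3ccoc3)cnc2c1N` carries furan-3-yl; in this assay compound 1 gives only a limit, > 120000 nM. Compound 2 `COC(=O)c1sc2cc(-c3cnn(C)c3)cnc2c1N` carries 1-methyl-1H-pyrazol-4-yl; for compound 2 this assay again reports only a limit, > 150000 nM. Compound 3 `COC(=O)c1sc2cc(-c3cccnc3)cnc2c1N` carries pyridin-3-yl, and for compound 3 the result is likewise a limit, > 112000 nM. Because all three values are limits (the limit of > 112000 nM in this assay, at which 1 of the 3 values shown sits, (the limit of > 120000 nM in this assay, at which 1 of the 3 values shown sits), (the limit of > 150000 nM in this assay, at which 1 of the 3 values shown sits)), the steps a step that the two limits leave unreadable from compound 1 to compound 2, a step that the two limits leave unreadable from compound 1 to compound 3 and a step that the two limits leave unreadable from compound 2 to compound 3 cannot be read in size or direction, and compound 3 stands among the others without any order between them.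

Compound 4 `COC(=O)c1sc2cc(-c3cccc(N)c3)cnc2c1N` has not yet been measured. It differs from compound 3 by 3-aminophenyl in place of pyridin-3-yl on an aromatic carbon. Going by the values given here, no measured step bears on this change with a readable size: each of the three steps among compounds 1, 2 and 3 is unreadable between limits. What is known is only that every aromatic substituent tried so far gave a limit in this assay. The step of an at least 1.1-fold lower number from compound 3 to compound 4 (0.04 log units; that floor lies within the scatter) is therefore expected to be none beyond the scatter, with another limit the most likely outcome. Compound 4 is estimated at 100000 nM in this assay, within a range from 20000 nM to 200000 nM.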

Compound 4, concentration for 50% growth inhibition: > 150000 nM
Compound 4: a limit, no number (the forecaster's own chance of this, stated with the estimate: 80%); at least 1.5-fold (0.17 log units) between middle value and limit.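

Compound 4, like compound 1, compound 2 and compound 3, gives only a limit in this assay, so its steps to those three compounds cannot be read in size or direction. The compounds shown leave open whether any aromatic substituent on the shared core gives a measurable number in this assay, and how these four compounds rank.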